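This account rests on a few compounds, and the source may have more. Where it says the series, first, only, none or still open, it means among the compounds named here.

Measured in a functional assay on KB cells (Homo sapiens) for antiproliferative activity, read by MTT assay, with a stated time of 72 h; a higher number here means a weaker inhibitor, a lower number a stronger inhibitor:
- Compound 1 `O=C1C=C(N2CCN(c3ccccc3Cl)CC2)C(=O)c2ccccc21`: 3700 nM
- Compound 2 `O=C1C=C(N2CCN(c3ccccc3Cl)CC2)C(=O)c2c(O)cccc21`: 4400 nM

Only these two compounds have been measured, and their values lie within the scatter of each other, so neither can be ranked above the other. Among the measured compounds shown here, the single measured step is a 1.2-fold higher number from compound 1 to compound 2 (0.08 log units; within the scatter), with hydroxy in place of hydrogen on an aromatic carbon.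

Compound 3 `Cc1ccccc1N1CCN(C2=CC(=O)c3cccc(O)c3C2=O)CC1` keeps that hydroxy and differs from compound 2 elsewhere, with methyl in place of chloro on an aromatic carbon, ortho to a large group (methyl in place of chloro on an aromatic carbon). For the measured compounds named here, the measured step involves a different change at a different place, so it bears on this exchange only indirectly, and no measured pair shows chloro replaced by methyl. The data therefore give no ground for expecting a shift in either direction in this assay, and the expectation starts from compound 2 at 4400 nM. The expected result is a 1.0-fold lower number from compound 2 to compound 3 (0.02 log units; within the scatter), a step no larger than the scatter. For compound 3 the estimated value is 4200 nM, with an expected range of 1800 nM to 10000 nM.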

Compound 3, half-maximal inhibitory concentration: 6600 nM
Beside the measured number, compound 3's estimate is 1.6-fold (0.20 log units) below it; the range from low to high includes it.
By their numbers in this assay, from the lowest: compounds 1, 2 and 3 (each within the scatter of the next).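

In this assay the exchange of chloro for methyl on the aromatic carbon ortho to a large group gives a 1.5-fold higher number from compound 2 to compound 3 (0.18 log units; within the scatter) and so provides the first reading at this position, where the earlier pair had shown only the hydroxy exchange elsewhere on the molecule. The step stays within the scatter, so the 2-chlorophenyl and 2-methylphenyl forms cannot be told apart in this read-out when the hydroxy of compound 2 is kept. No measured evidence is available that could explain this result.

Among the compounds shown here, what an amine, a methoxy or a carboxylic acid would give at the same aromatic carbon remains open, since chloro and methyl are the only groups seen there, and both are small and carry no hydrogen-bond donors or acceptors. For the compounds shown here, also open is whether chloro and methyl would still read alike on the core of compound 1, which lacks the hydroxy, because the exchange has been seen only with the hydroxy in place.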